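Series notes: chloro to methoxy step toward compound 4

The source may report more compounds than this note shows. Statements on the series, on what has been measured and on what is new or still open speak of the compounds shown alone.

Measured so far:
compound 1 `O=S(=O)(c1cccc(F)c1)c1cnc2c(F)cccc2c1-c1ccc(Cl)cc1` — 0.62 mL/min
compound 2 `O=S(=O)(c1cc(F)cc(F)c1)c1cnc2c(F)cccc2c1-c1ccc(Cl)cc1` — 0.73 mL/min
compound 3 `O=S(=O)(c1ccc(F)c(Cl)c1)c1cnc2c(F)cccc2c1-c1ccc(Cl)cc1` — 0.01 mL/min

In an ADME assay on microsomes from liver (Homo sapiens) for metabolic stability, tested at 2.5 uM (on this read-out higher numbers stand for fast clearance and lower numbers for slow clearance), compound 1 stands second highest of the three. Compound 2 sits within the scatter of it (a 1.2-fold higher number from compound 1 to compound 2 (0.07 log units; within the scatter)), while compound 3 lies far lower (a 62-fold lower number from compound 1 to compound 3 (1.79 log units; beyond the scatter)), and the same holds for a 73-fold lower number from compound 2 to compound 3 (1.86 log units; beyond the scatter).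

Compound 4 `COc1ccc(-c2c(S(=O)(=O)c3cccc(F)c3)cnc3c(F)cccc23)cc1` is not yet measured. Relative to compound 1 the change is methoxy in place of chloro on an aromatic carbon. Going by the values given here, none of the measured steps bears on this place: each of them alters the group on the sulfonyl sulfur, which is unchanged here, as is the shared core. No direction can therefore be read off, and the expectation rests on compound 1 alone with a wide range. Compound 4 is expected near 0.7 mL/min (range 0.2 mL/min to 2.5 mL/min), an expected step of a 1.1-fold higher number from compound 1 to compound 4 (0.05 log units; within the scatter).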

Compound 4, intrinsic clearance in a liver preparation (reported as CLH), per the amount of preparation that the assay uses: 2.48 mL/min
Estimate against measurement, compound 4: 3.5-fold (0.55 log units) below, and the stated range covers the measured number.
By their numbers in this assay, from the lowest: compound 3; then compounds 1 and 2 (each within the scatter of the next); then compound 4.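

The group para to the large group on this ring does register in this assay: the change from 4-chlorophenyl to 4-methoxyphenyl gives a 4.0-fold higher number from compound 1 to compound 4 (0.60 log units; beyond the scatter). Going by these compounds alone, this is the first step away from the group on the sulfonyl sulfur, and it runs towards faster clearance. Nothing at hand accounts for this step.

Open, on these data alone, is whether a hydroxyl, an ethoxy or a dimethylamino group at this place would follow methoxy or stay near chloro. Also open, as far as these compounds go, is whether the step would carry over with the 3-chloro-4-fluorophenyl group of compound 3 on the sulfonyl sulfur.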